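Replacing the dioxolanyl group of compound 3

This account rests on a few compounds, and the source may have more. Where it says the series, first, only, none or still open, it means among the compounds named here.

Compound 3 `CC1(C)OC[C@H](Cn2cc(-c3ccc(C(F)(F)F)cc3)nn2)O1` carries 2,2-dimethyl-1,3-dioxolan-4-yl on the chain carbon bound to the aromatic nitrogen and trifluoromethyl on the aryl ring. In a functional assay on B16 cells (Mus musculus) for cytotoxicity, read by MTT assay, with a stated time of 48 h (a lower number here means a stronger inhibitor, a higher number a weaker inhibitor), compound 3 gives only a limit, > 100000 nM, so no number is known for it; this is the limit of > 100000 nM in this assay, at which 1 of the 3 values shown sits.

Two measured compounds share the alternative carrier. Compound 1 `COc1cccc(Cn2cc(-c3ccc([N+](=O)[O-])cc3)nn2)c1` gives 19100 nM in this assay. Compound 2 `COc1cccc(Cn2cc(-c3ccc(C)cc3)nn2)c1` gives 19500 nM. Among the compounds with values here, the one measured step, a 1.0-fold higher number from compound 1 to compound 2 (0.01 log units; within the scatter), concerns the substituent on the aryl ring and not the chain carbon, so it does not bear directly on the present change; it does show that swapping the aryl substituent left the number essentially unchanged.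

Compound 4 `COc1cccc(Cn2cc(-c3ccc(C(F)(F)F)cc3)nn2)c1` is the unmeasured partner of compound 3. The change is 3-methoxyphenyl in place of 2,2-dimethyl-1,3-dioxolan-4-yl on a saturated chain carbon bound to an aromatic nitrogen. Within the data shown here, compound 4 thus holds the same carrier as compound 1 and compound 2 and differs from them only on the aryl ring, where the one measured step was flat. The number for compound 4 is therefore expected to lie close to those of compound 1 and compound 2, and since compound 3 sits at the limit the expected step is an at least 5.0-fold lower number from compound 3 to compound 4 (0.69 log units; beyond the scatter), towards a lower number. Compound 4 is estimated at 20000 nM, with a range from 7000 nM to 60000 nM.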

Compound 4, half-maximal inhibitory concentration: 17400 nM
For compound 4 the middle estimate is 1.1-fold (0.06 log units) above the measured one; the measured number falls inside the stated range.
By their numbers in this assay, from the lowest: compounds 4, 1 and 2 (each within the scatter of the next). At a limit, above all of these: compound 3.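

Placing 3-methoxyphenyl in place of 2,2-dimethyl-1,3-dioxolan-4-yl on a saturated chain carbon bound to an aromatic nitrogen, with trifluoromethyl held on the aryl ring, gives a direct reading of this change in this assay, namely an at least 5.7-fold lower number from compound 3 to compound 4 (0.75 log units; beyond the scatter) and so a clear change at this position. That reading is only a bound, since compound 3 gives a limit and not a number: the limit of > 100000 nM in this assay, at which 1 of the 4 values shown sits. With 3-methoxyphenyl held, trifluoromethyl joins nitro and methyl on the aryl ring without a readable shift, as shown by a 1.1-fold lower number from compound 2 to compound 4 (0.05 log units; within the scatter) and by a 1.1-fold lower number from compound 1 to compound 4 (0.04 log units; within the scatter) and so the flat aryl picture now extends across compounds 1, 2 and 4.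

On these data alone, the true size of the step from compound 3 stays open, as does whether the flat aryl picture holds with 2,2-dimethyl-1,3-dioxolan-4-yl on the chain carbon. Also open, as far as these compounds go, is whether the change depends on the methoxy group, the aromatic ring or the loss of the dioxolanyl ring, a question that an unsubstituted phenyl or a morpholine on the same chain carbon would help to separate.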